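The source may hold more compounds than are shown below. What is called first, only, known or untested is meant among the compounds shown, and "the series" means these compounds.

Compound 1 `Cc1ccccc1Nc1nc(NCc2ccccc2)ncc1Cl`: > 100000 nM
Compound 2 `CN1CCN(c2ccc(Nc3ncc(Cl)c(Nc4ccccc4)n3)nc2)CC1`: 7990 nM

For the measured compounds named here, in an ADME assay on L02 cells (Homo sapiens) for inhibition, read by CCK-8 assay, with a stated time of 48 h (a higher number here means a weaker inhibitor of growth, a lower number a stronger inhibitor of growth), compound 2 gives 7990 nM, the only actual number so far. The entry for compound 1, > 100000 nM, is a limit of the assay and not a number.

Still unmeasured is compound 3 `COc1ccc(CNc2nc(Nc3ccc(N4CCN(C)CC4)cn3)ncc2Cl)cc1`. It differs from compound 2 by having 4-methoxybenzyl in place of phenyl on a nitrogen on an aromatic ring. Going by the values given here, no measured pair shows what such a swap does in this assay, so the direction cannot be called with any confidence. The best starting point is therefore compound 2 at 7990 nM, with a wide margin on either side. The expected change is a 1.0-fold higher number from compound 2 to compound 3 (0.00 log units; within the scatter), which means no shift beyond the usual scatter. For compound 3 the estimated value is 8000 nM, with an expected range from 2500 nM to 30000 nM.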

Compound 3, concentration for 50% growth inhibition: 12900 nM
Compound 3: the middle estimate sits 1.6-fold (0.21 log units) below what was measured; measured number inside the range.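

In this assay, putting 4-methoxybenzyl in place of phenyl on this nitrogen gives a 1.6-fold higher number from compound 2 to compound 3 (0.21 log units; within the scatter) and so no real change in growth inhibition. For the compounds shown here, this is the first reading at this position, and it shows that a larger group, with 9 heavy atoms instead of 6 and one hydrogen-bond acceptor instead of none, leaves the number within the scatter for this pair. Nothing measured here offers a reason for this outcome.

Going by these compounds alone, the single step combines two changes, the added carbon between ring and nitrogen and the added methoxy group, so an unsubstituted benzyl would be needed to separate them. From the compounds shown here alone, whether a carboxylic acid or a dimethylamino-bearing longer chain on this nitrogen would move the number beyond the scatter remains open.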